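Estimating compound 4 from the step between compounds 1 and 3

The source may hold more compounds than are shown below. What is called first, only, known or untested is meant among the compounds shown, and "the series" means these compounds.

Measured so far:
Compound 1 `COc1cc(NC(=O)Nc2cc(Nc3ccc(C(C)(C)C)cc3)ncn2)cc(OC)c1`: 32.7%
Compound 2 `Cc1cc(F)cc(Nc2cc(NC(=O)Nc3c(Cl)cccc3Cl)ncn2)c1`: 49.1%
Compound 3 `COc1cc(NC(=O)Nc2cc(Nc3cccc(C(C)(C)C)c3)ncn2)cc(OC)c1`: 48.7%

In a functional assay on HCC827 cells (Homo sapiens) for inhibition, read by MTT assay, with a stated time of 48 h, tested at 10 uM (on this read-out higher numbers stand for more inhibition at the one concentration tested (going by the name of the read-out) and lower numbers for less inhibition), compound 3 stands second highest of the three numbers. Its nearest neighbour is compound 2, which gives 49.1%, within the scatter of compound 3. Among the measured compounds shown here, compound 1 lies furthest away, and the only single-place step among the measured compounds is a number 16 percentage points higher from compound 1 to compound 3 (beyond the scatter), a modest gain beyond the scatter.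

Compound 4 `COc1cc(NC(=O)Nc2cc(Nc3ccc(C)c(F)c3)ncn2)cc(OC)c1` differs from compound 3 by 3-fluoro-4-methylphenyl in place of 3-(tert-butyl)phenyl on a nitrogen on an aromatic ring. For the measured compounds named here, no measured step replaces the tert-butyl group by another group, so the step from compound 1 to compound 3 bears on it only indirectly: it shows the read-out responds to where the group on that ring sits, but not what happens when the group itself is exchanged. Compound 2, which also carries a fluorine and a methyl on that ring, differs in a second place as well, so its value only shows that such a ring can sit near compound 3 in this assay.

Compound 4 is therefore expected to give about 40% in this assay, with a range from 25% to 55%. This corresponds to an expected step of a number 8.7 percentage points lower from compound 3 to compound 4 (within the scatter), at the edge of the scatter and most likely a small loss.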

Compound 4, a percentage reported as inhibition, at one concentration (the size of the read-out at that concentration, not a potency): 72%
Compound 4: middle estimate off by 32 percentage points, on the low side; measured number above the stated range.
By their numbers in this assay, from the lowest: compound 1; then compounds 3 and 2 (each within the scatter of the next); then compound 4.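

In this assay, the tert-butyl group itself is now exchanged rather than moved: 3-fluoro-4-methylphenyl in place of 3-(tert-butyl)phenyl on a nitrogen on an aromatic ring gives a number 23.3 percentage points higher from compound 3 to compound 4 (beyond the scatter). The same group in place of 4-(tert-butyl)phenyl gives a number 39.3 percentage points higher from compound 1 to compound 4 (beyond the scatter), so the read-out at this position depends on the identity of the group as well as on where the tert-butyl group sits. No measurement available here accounts for either gain.

The fluorine and the methyl enter together, so the compounds shown do not separate what each contributes, and a ring carrying only one of them remains open. Also open, on these data alone, is how this position responds to a ring bearing an amine or a carboxylic acid.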